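Swapping the Aryl Ring on a Five-Membered Core

A few compounds are considered here, and "the series" means these few. Any claim that something is new, unique, unknown or untested is made for them only; others in the source may bear on it.

Measured so far:
compound 1, `COc1cc(C(=O)N/N=C/c2cccc(F)c2)cc(OC)c1OC`: 64.1%
compound 2, `COc1cc(C2=NN(C(C)=O)C(c3cccc(OC)c3OC)O2)cc(OC)c1OC`: 58.2%

Both compounds were tested in a functional assay on PC-3 cells (Homo sapiens) for antiproliferative activity, read by MTT assay, tested at 5 uM; a higher number here means a stronger effect of the compound at the concentration tested, a lower number a weaker effect. Compound 1 gives 64.1% and compound 2 gives 58.2%. Compound 2 holds the lower of the two numbers, yet the gap to compound 1 lies within the usual scatter, so the two compounds cannot be told apart on this evidence.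

Compound 3, `COc1cc(C2=NN(C(C)=O)C(c3ccc(Cl)c([N+](=O)[O-])c3)O2)cc(OC)c1OC`, has not yet been measured in this assay. It differs from compound 2 in a single place: 4-chloro-3-nitrophenyl in place of 2,3-dimethoxyphenyl on a saturated ring carbon. Within the data shown here, no pair of measured compounds shows what such a swap does, so nothing in the data fixes either the direction or the size of the step.

In the absence of a comparable step, the expectation is that the change from compound 2 to compound 3 stays close to the scatter, with no clear direction. Compound 3 is therefore estimated to give 55% in this assay, within a range from 35% to 75%, which corresponds to an expected step of a number 3.2 percentage points lower from compound 2 to compound 3 (within the scatter).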

Compound 3, a percentage reported as inhibition, at one concentration (the size of the read-out at that concentration, not a potency): 61.4%
Beside the measured number, compound 3's estimate is 6.4 percentage points below it; the measured number falls inside the stated range.
By their numbers in this assay, from the lowest: compounds 2, 3 and 1 (each within the scatter of the next).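

In this assay, the first step measured at this saturated ring carbon is a number 3.2 percentage points higher from compound 2 to compound 3 (within the scatter), so this swap does not separate the two compounds. The groups that trade places have the same counts of heavy atoms and hydrogen-bond acceptors but are built differently: 2,3-dimethoxyphenyl carries only carbon and oxygen, while 4-chloro-3-nitrophenyl also brings nitrogen and chlorine, so in this one pair the position accepts a marked change in the aryl ring's substituents without a readable change in the result. Nothing available here measures a property that could account for this outcome.

Both groups compared at this position are substituted phenyl rings, so the compounds shown leave open whether a ring-free group such as a short alkyl chain, a saturated ring such as cyclohexyl, or a phenyl ring bearing an amine or a carboxylic acid would give a similar result. Because the read-out comes from a single concentration, they also leave open whether compound 2 and compound 3 would still look alike across a range of concentrations.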